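Sulfoxide for nitrile on the ether chain

The compounds below may be only part of what the source reports. "The series", "measured", "known", "first", "only" and "open" are said of these compounds alone.

Measured compounds:
compound 1 `CSCc1cc(C(C)=O)c(O)cc1OCCCCCCC#N` — 64%
compound 2 `CCc1cc(C(C)=O)c(O)cc1OCCCCC(C)(C)C#N` — 30%

In an assay on isolated protein for binding affinity to leukotriene B4 receptor 1 (Homo sapiens), tested at 1 uM (on this read-out lower numbers stand for less inhibition and higher numbers for more inhibition at the one concentration tested (going by the name of the read-out)), compound 2 gives the lowest of the two numbers; compound 1 stands higher by a gap beyond the scatter. Compound 3 `CCc1cc(C(C)=O)c(O)cc1OCCCCCC[S+](C)[O-]` has not yet been measured. Its change from compound 2 is a group of 5 heavy atoms (3 carbon, 1 oxygen, 1 sulfur; no ring) in place of a group of 5 heavy atoms (4 carbon, 1 nitrogen; no ring), on a saturated chain carbon, four bonds along the chain from an oxygen on an aromatic ring. Going by the values given here, no measured pair shows this step, so its size is unknown from the data; a moderate rise is expected, and the estimated step of a number 10 percentage points higher from compound 2 to compound 3 (within the scatter) could also turn out to be none beyond the scatter. For compound 3 the estimate is 40%, with a range from 15% to 65%.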

Compound 3, a percentage reported as inhibition, at one concentration (the size of the read-out at that concentration, not a potency): 50%
Compound 3: middle estimate off by 10 percentage points, on the low side; low and high end bracket the measured number.
By their numbers in this assay, from the lowest: compound 2; then compound 3; then compound 1.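

Going by these compounds alone, replacing 1-cyano-1-methylethyl with the sulfoxide, on a saturated chain carbon, four bonds along the chain from an oxygen on an aromatic ring, gives the first sized change at this position: a number 20 percentage points higher from compound 2 to compound 3 (beyond the scatter) in this assay. The read-out therefore responds to the group at this place, even though both groups have 5 heavy atoms, no ring and 1 hydrogen-bond acceptor. No measurement in hand accounts for the step.

From the compounds shown here alone, a sulfone or a carboxylic acid at this place remains open, as does whether the same step holds on the core of compound 1.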